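The compounds below may be only part of what the source reports. "The series", "measured", "known", "first", "only" and "open" are said of these compounds alone.

Measured compounds:
- compound 1, `COc1ccc(-c2cc(/C=C/C(=O)c3ccc(N)cc3)[nH]n2)cc1`: 3840 nM
- compound 2, `COc1ccc(-c2cc(/C=C/C(=O)c3ccc(N)cc3)[nH]n2)cc1OC`: 8480 nM
- compound 3, `COc1cc(C(=O)/C=C/c2cc(-c3cc(OC)c(OC)c(OC)c3)n[nH]2)cc(OC)c1OC`: 2070 nM

All three were tested in a functional assay on MCF7 cells (Homo sapiens) for inhibition, read by sulforhodamine B assay, with a stated time of 48 h; on this read-out higher numbers stand for weaker inhibition of growth and lower numbers for stronger inhibition of growth. Compound 1 and compound 2 share one core and differ in a single place: hydrogen in place of methoxy on an aromatic carbon. This step gave a 2.2-fold lower number from compound 2 to compound 1 (0.34 log units; beyond the scatter). Compound 3 carries a different core; how that core differs from the core of compound 2 is not broken down here. Within this assay compound 3 has the lowest number of the three, with compound 1 within the scatter of it and compound 2 beyond it.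

Compound 4, `COc1ccc(-c2cc(/C=C/C(=O)c3cc(OC)c(OC)c(OC)c3)[nH]n2)cc1OC`, is not yet measured. It differs from compound 3 in one place: hydrogen in place of methoxy on an aromatic carbon. For the measured compounds named here, this is the same kind of change as the one from compound 2 to compound 1, though the surroundings are not identical: in compound 3 the site is also meta to a methoxy group, which is not so in compound 2. Since the step from compound 2 to compound 1 gave a 2.2-fold lower number from compound 2 to compound 1 (0.34 log units; beyond the scatter), a step of similar direction and modest size is expected for compound 4, a 1.7-fold lower number from compound 3 to compound 4 (0.24 log units; within the scatter), with the usual scatter and the changed surroundings leaving room for it to fall anywhere from little change to a somewhat larger drop. In this assay compound 4 is therefore estimated at 1200 nM, expected to lie between 400 nM and 4000 nM.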

Compound 4, concentration for total growth inhibition: 2500 nM
Estimate against measurement, compound 4: 2.1-fold (0.32 log units) below; measured number inside the range.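

In this assay, the replacement of methoxy by hydrogen on an aromatic carbon does not carry over unchanged from one core to the other, as the two steps differ: the same change on two cores in this assay, a 2.2-fold lower number (0.34 log units; beyond the scatter) from compound 2 to compound 1 and a 1.2-fold higher number (0.08 log units; within the scatter) from compound 3 to compound 4, 2.7-fold (0.43 log units) apart, beyond the scatter of two such steps

On the core of compound 3, the change gives a 1.2-fold higher number from compound 3 to compound 4 (0.08 log units; within the scatter), so no effect of removing this methoxy can be read there, whereas the step on the core of compound 1 lay beyond the scatter. For the compounds shown here, the comparison rests on only two pairs, so it warns against using one step to predict the other, but it does not show which difference between the cores lies behind the gap or how a third core would respond.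

The compounds shown leave open whether a fluorine, a hydroxyl or an ethoxy group at this aromatic carbon would separate the two cores in the same way, since only methoxy and hydrogen are compared here. They also leave open how this assay would respond on either core to a group of another kind, such as a carboxylic acid or a longer alkoxy chain, at the same carbon.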